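This account rests on a few compounds, and the source may have more. Where it says the series, first, only, none or still open, it means among the compounds named here.

Compound 1 `CNc1nc(NCc2ccc(NC(=O)c3ccc(F)cc3)cc2)c2ccc(C)cc2n1`: > 0.5 h, which is a limit and not a number.
Compound 2 `Cc1ccc2c(NCc3ccc(NC(=O)c4ccc(F)cc4)cc3)nc(N3CCNCC3)nc2c1`: 0.0833 h.

Among the measured compounds shown here, in an in vitro ADME assay on microsomes from liver (Rattus norvegicus) for metabolic stability (on this read-out higher numbers stand for a longer-lived compound and lower numbers for a shorter-lived compound), compound 2 holds the only true number, and it lies on the short-lived side of the one other result. Compound 3 `Cc1ccc2c(NCc3ccc(NC(=O)c4ccc(F)cc4)cc3)nc(N3CCN[C@H](C)C3)nc2c1` alters compound 2 by a small edit: methyl in place of hydrogen on a saturated ring carbon. For the measured compounds named here, only one measured step bears on this, an at least 6.0-fold lower number from compound 1 to compound 2 (0.77 log units; beyond the scatter), and it exchanged a whole group, whereas here a methyl replaces a hydrogen on the piperazine. A much smaller change is therefore expected, probably none beyond the scatter. The expected step is a 1.2-fold higher number from compound 2 to compound 3 (0.08 log units; within the scatter). The estimate for compound 3 is 0.1 h, with an expected range of 0.05 h to 0.25 h.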

Compound 3, half-life in the Rattus norvegicus assay: 0.0667 h
For compound 3 the middle estimate is 1.5-fold (0.18 log units) above the measured one; measured number inside the range.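

In the Rattus norvegicus assay, compound 2 gives 0.0833 h and compound 3 gives 0.0667 h, so a methyl on this saturated ring carbon of the piperazine makes no change beyond the scatter (a 1.2-fold lower number from compound 2 to compound 3 (0.10 log units; within the scatter)). The same holds in a physicochemical assay for solubility, at pH 7.4 (on this read-out higher numbers stand for higher solubility and lower numbers for lower solubility), where compound 2 gives 22 ug/mL and compound 3 gives 27 ug/mL (a 1.2-fold higher number from compound 2 to compound 3 (0.09 log units; within the scatter)). In the Rattus norvegicus assay, the gap to the methylamino compound remains wide (an at least 7.4-fold lower number from compound 1 to compound 3 (0.87 log units; beyond the scatter)), though compound 1 offers only a limit and not a number, so that gap has only a minimum size: (the limit of > 0.5 h in the Rattus norvegicus assay, at which 1 of the 3 values shown sits).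

Still open, as far as these compounds go, is whether a larger group on this carbon, such as ethyl or hydroxymethyl, would shift the half-life. Also open, from the compounds shown here alone, is whether an acetyl on the ring nitrogen would do so.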